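Swapping Fluoro for Hydroxy on a Weak Inhibitor

The source may hold more compounds than are shown below. What is called first, only, known or untested is meant among the compounds shown, and "the series" means these compounds.

Measured so far in an assay on isolated protein for inhibition of lysosomal alpha-glucosidase (Rattus norvegicus), read by colorimetric assay; a lower number here means a stronger inhibitor, a higher number a weaker inhibitor:
compound 1, `OC[C@@]1(c2ccc(F)cc2)NC[C@@H](O)[C@@H]1O`, gives 12000 nM
compound 2, `OC[C@]1(c2ccc(F)cc2)NC[C@H](O)[C@H]1O`, gives 101000 nM
compound 3, `C[C@@]1(CO)NC[C@H](O)[C@H]1O`, gives 2900 nM

Compound 2 has the highest number of the three, so it is the weakest inhibitor shown. Among the compounds with values here, the only step measured in one place is an 8.4-fold higher number from compound 1 to compound 2 (0.93 log units; beyond the scatter), a modest change that rests on (the fact that compounds 1 and 2 differ only in the configuration as drawn). Compound 4, `OC[C@]1(c2ccc(O)cc2)NC[C@H](O)[C@H]1O`, is made from compound 2 by hydroxy in place of fluoro on an aromatic carbon. Within the data shown here, no measured step touches the aromatic ring, so the stereochemical step gives no guide to this change. The expected outcome is a 1.3-fold lower number from compound 2 to compound 4 (0.10 log units; within the scatter), a shift not beyond the scatter. Compound 4 is therefore expected to give about 80000 nM, between 20000 nM and 320000 nM.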

Compound 4, half-maximal inhibitory concentration: 2600 nM
Estimate against measurement, compound 4: 31-fold (1.49 log units) above, and the stated range ends above it.
By their numbers in this assay, from the lowest: compounds 4 and 3 (each within the scatter of the next); then compound 1; then compound 2.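

In this assay, within the data shown here, exchanging one heavy atom on the aromatic ring gives a 39-fold lower number from compound 2 to compound 4 (1.59 log units; beyond the scatter), so this position matters far more than the earlier compounds could reveal. The hydroxy brings a hydrogen-bond donor and acceptor that fluoro lacks, yet nothing shown explains the size of this step. Going by these compounds, whether hydroxy in place of fluoro does the same on compound 1, with its inverted configuration, remains open. Also open, on these data alone, is what an amine or a methoxy group would give at this place on the ring.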